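This account rests on a few compounds, and the source may have more. Where it says the series, first, only, none or still open, it means among the compounds named here.

Of the compounds shown here, three built on a shared core have been tested in a functional assay on WI-38 VA13 cells (Homo sapiens) for cytotoxicity; a lower number here means that less compound is needed, a higher number that more compound is needed for the effect. Compound 1 `O=C(Nc1ccc2nc(NC(=O)C3CCCCC3)sc2c1)c1ccccc1Cl` gives 0.025 ug/mL, compound 2 `O=C(Nc1ccc2nc(NC(=O)C3CCCCC3)sc2c1)c1ccccc1Oc1ccccc1` gives 0.1 ug/mL, and compound 3 `COc1ccc(C(=O)Nc2ccc3nc(NC(=O)C4CCCCC4)sc3c2)cc1` gives 4.9 ug/mL. Compound 3 therefore has the highest number of the three, so the most material is needed for its effect; compound 2 stands nearest to it and compound 1 farthest. Putting phenoxy in place of chloro on an aromatic carbon gave a 4.0-fold higher number from compound 1 to compound 2 (0.60 log units; beyond the scatter), and putting 4-methoxyphenyl in place of 2-chlorophenyl on a carbonyl carbon gave a 200-fold higher number from compound 1 to compound 3 (2.29 log units; beyond the scatter). Compound 4 `O=C(Nc1ccc2nc(NC(=O)C3CCCCC3)sc2c1)c1c(Cl)cccc1Cl` has not yet been measured. Against compound 3 the change is 2,6-dichlorophenyl in place of 4-methoxyphenyl on a carbonyl carbon. For the measured compounds named here, the step that bears on this is the one from compound 1 to compound 3, which was large; compound 4 brings back a chlorine-bearing ring where compound 3 carries the methoxy ring, so a large fall in the number is expected. Compound 4 is expected to give about 0.03 ug/mL in this assay, with a range of 0.008 ug/mL to 0.15 ug/mL. The expected step is a 160-fold lower number from compound 3 to compound 4 (2.21 log units; beyond the scatter).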

Compound 4, half-maximal effective concentration: 0.015 ug/mL
Beside the measured number, compound 4's estimate is 2.0-fold (0.30 log units) above it, within the range that was stated.
By their numbers in this assay, from the lowest: compounds 4 and 1 (each within the scatter of the next); then compound 2; then compound 3.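

In this assay, this carbonyl carbon proves highly sensitive to the ring it carries: 2,6-dichlorophenyl in place of 4-methoxyphenyl gives a 330-fold lower number from compound 3 to compound 4 (2.51 log units; beyond the scatter). The second chlorine, however, adds nothing that can be read, since chloro in place of hydrogen on an aromatic carbon gives a 1.7-fold lower number from compound 1 to compound 4 (0.22 log units; within the scatter), which lies within the scatter, so the 2-chlorophenyl and 2,6-dichlorophenyl rings cannot be told apart here. No measurement is available to explain the gap between these chlorine-bearing rings and the methoxy ring.

As far as these compounds go, it remains open whether the large step follows the chloro and methoxy groups themselves or the ring positions in their names: 4-chlorophenyl and 2-methoxyphenyl groups on the same carbonyl carbon would separate the two. From the compounds shown here alone, how an amine or a carboxylic acid on this ring would behave also remains open.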